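The source may hold more compounds than are shown below. What is called first, only, known or untested is meant among the compounds shown, and "the series" means these compounds.

Compound 2 `CCOC(=O)CCCCCOc1cccc(CN(C(=O)c2ccc(-c3cccc(C(C)=O)c3)cc2)C(C)C)c1` in an ADME assay on BJ cells (Homo sapiens) for cytotoxicity, read by CellTiter-Glo and resazurin assay, with a stated time of 72 h (a lower number here means that less compound is needed, a higher number that more compound is needed for the effect), gives > 26000 nM, which is a limit of the assay rather than a number. Compound 1 `CC(=O)c1cccc(-c2ccc(C(=O)N(Cc3cccc(OCCCCCC(=O)O)c3)C(C)C)cc2)c1` gives > 26000 nM, likewise a limit. Compound 3 `CCOC(=O)CCCCCOc1cccc(CN(C(=O)c2ccc(-c3cccc(OCc4ccccc4)c3)cc2)C(C)C)c1` gives > 26000 nM, again a limit. All three values therefore share (the limit of > 26000 nM in this assay, at which 3 of the 3 values shown sit), and both measured steps, a step that the two limits leave unreadable from compound 1 to compound 2 and a step that the two limits leave unreadable from compound 2 to compound 3, cannot be given a size. Compound 4 `CCOC(=O)CCCCCOc1cccc(CN(C(=O)c2ccc(-c3ccc4c(c3)OCCO4)cc2)C(C)C)c1` differs from compound 2 by 2,3-dihydro-1,4-benzodioxin-6-yl in place of 3-acetylphenyl on an aromatic carbon. Among the compounds with values here, no measured step offers a readable size for this change, so no step beyond the scatter is expected in this assay. Compound 4 is therefore expected to give 40000 nM, within a range of 20000 nM to 100000 nM, most probably reported again only as a limit. The expected step is a step that the limit leaves unreadable from compound 2 to compound 4.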

Compound 4, half-maximal effective concentration: > 24400 nM
Compound 4 gave a limit, no number; the forecaster's own chance of this, stated with the estimate: 85%; the middle value is on the limit's open side.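

Compound 2 and compound 4 both stand only as limits, so no step can be read between them. The compounds shown leave open whether any of these structures reaches a measurable value in this assay.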